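Cytotoxicity notes: compound 4 from compound 3

The source may report more compounds than this note shows. Statements on the series, on what has been measured and on what is new or still open speak of the compounds shown alone.

Compound 1 `CC(C)N(Cc1cccc(OCCCCCC(=O)O)c1)C(=O)c1ccccc1` in an ADME assay on HEK293 cells (Homo sapiens) for cytotoxicity, read by CellTiter-Glo and resazurin assay, with a stated time of 72 h (a higher number here means that more compound is needed for the effect, a lower number that less compound is needed), gives > 26000 nM, a limit of the assay.
Compound 2 `CC(C)COc1cccc(-c2ccc(C(=O)N(Cc3cccc(OCCCCCC(=O)O)c3)C(C)C)cc2)c1` in this assay gives > 26000 nM, again a limit.
Compound 3 `CC(C)Oc1cccc(-c2ccc(C(=O)N(Cc3cccc(OCCCCCC(=O)O)c3)C(C)C)cc2)c1` in this assay gives > 26000 nM, also a limit.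

Compound 3 thus stands only at a limit. All three measured values sit at the limit of > 26000 nM in this assay, at which 3 of the 3 values shown sit. Compound 4 `COc1cc(OC)cc(-c2ccc(C(=O)N(Cc3cccc(OCCCCCC(=O)O)c3)C(C)C)cc2)c1` differs from compound 3 by 3,5-dimethoxyphenyl in place of 3-isopropoxyphenyl on an aromatic carbon. The measured steps that bear on this aromatic position, a step that the two limits leave unreadable from compound 1 to compound 2, a step that the two limits leave unreadable from compound 1 to compound 3 and a step that the two limits leave unreadable from compound 2 to compound 3, are all unreadable; no size and no direction can be taken from them. Nothing in this assay separates the three aryl variants. Compound 4 is expected at 30000 nM, within 15000 nM to 80000 nM, most probably reported again only as a limit. The expected step that the limit leaves unreadable from compound 3 to compound 4 is none beyond the scatter.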

Compound 4, half-maximal effective concentration: > 26000 nM
Compound 4: a limit, no number (the forecaster's own chance of this, stated with the estimate: 85%); the middle value does not contradict the limit.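

For the compounds shown here, compound 4 joins compounds 1, 2 and 3 at the same assay limit, so no step among them can be read: the limit of > 26000 nM in this assay, at which 4 of the 4 values shown sit.
Going by these compounds, whether the aryl group at this position changes the half-maximal effective concentration at all in this assay stays open.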